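Cytotoxicity notes: ethyl triazole phthalimide thioethers

A few compounds are considered here, and "the series" means these few. Any claim that something is new, unique, unknown or untested is made for them only; others in the source may bear on it.

Measured compounds:
compound 1 `CCc1nnc(SCc2ccccc2)n1N1C(=O)c2ccccc2C1=O` gives > 200000 nM in a functional assay on HepG2 cells (Homo sapiens) for cytotoxicity, read by MTT assay, with a stated time of 48 h (a lower number here means a stronger inhibitor, a higher number a weaker inhibitor), a limit of the assay.
compound 2 `CCc1nnc(SCC(=O)c2ccccc2)n1N1C(=O)c2ccccc2C1=O` gives > 200000 nM in this assay, a limit.
compound 3 `CCc1nnc(SCC(=O)c2ccc(C)cc2)n1N1C(=O)c2ccccc2C1=O` gives > 200000 nM in this assay, a limit.

Compound 3 stands at the limit of > 200000 nM in this assay, at which 3 of the 3 values shown sit; it is not separated from the others by any readable number. The steps a step that the two limits leave unreadable from compound 1 to compound 2, a step that the two limits leave unreadable from compound 1 to compound 3 and a step that the two limits leave unreadable from compound 2 to compound 3 therefore carry no measurable size, and none of them speaks for or against a shift on further change of the group on the sulfur-bound chain carbon.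

Compound 4 `CCc1nnc(SC)n1N1C(=O)c2ccccc2C1=O` differs from compound 3 by hydrogen in place of (4-methylphenyl)carbonyl on a saturated chain carbon bound to a sulfur. Among the compounds with values here, with every measured neighbour sitting at the limit, no step shows that this position moves the read-out in this assay at all. The expectation is that compound 4 also gives no number, the step that the limit leaves unreadable from compound 3 to compound 4 being the estimate; compound 4 is expected near 300000 nM, within 100000 nM to 1000000 nM.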

Compound 4, half-maximal inhibitory concentration: > 200000 nM
Compound 4: only a limit was reported; the forecaster's own chance of this, stated with the estimate: 85%; the middle value lies beyond the limit too.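

No step among compound 1, compound 2, compound 3 and compound 4 can be read: the limit of > 200000 nM in this assay, at which 4 of the 4 values shown sit.

Left open is whether any group on the saturated chain carbon bound to a sulfur gives a readable number in this assay.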